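Cyano exchange on compound 3: working notes

The source may report more compounds than this note shows. Statements on the series, on what has been measured and on what is new or still open speak of the compounds shown alone.

Going by the values given here, in a functional assay on KB cells (Homo sapiens) for inhibition (on this read-out lower numbers stand for stronger inhibition and higher numbers for weaker inhibition), compound 3 `NC(=S)c1c(N)n(COCc2ccccc2)c2ncnc(N)c12` gives 225000 nM, the only actual number so far. Compound 1 `COCCOCN1c2ncnc(N)c2C(C(=N)S)C1N` reads > 320000 nM, which is a limit of the assay. Compound 2 `C=CCn1c(N)c(C#N)c2c(N)ncnc21`, which also carries cyano, reads > 100000 nM, likewise a limit. Compound 4 `N#Cc1c(N)n(COCc2ccccc2)c2ncnc(N)c12` differs from compound 3 on an aromatic carbon: a group of 2 heavy atoms (1 carbon, 1 nitrogen; no ring) in place of a group of 3 heavy atoms (1 carbon, 1 nitrogen, 1 sulfur; no ring), on an aromatic carbon. Among the compounds with values here, no measured pair isolates this exchange, so the expectation rests on compound 3 at 225000 nM. The expected change in this assay is a 1.3-fold lower number from compound 3 to compound 4 (0.12 log units; within the scatter), with no step beyond the scatter and no firm direction. For compound 4 the estimate is 170000 nM, with an expected range of 40000 nM to 500000 nM.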

Compound 4, half-maximal inhibitory concentration: 118000 nM
Estimate against measurement, compound 4: 1.4-fold (0.16 log units) above; measured number inside the range.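

In this assay, cyano on this aromatic carbon, two ring bonds from the ring nitrogen, gives a 1.9-fold lower number from compound 3 to compound 4 (0.28 log units; within the scatter). Going by these compounds alone, this is the first step that can be read at this position, and it shows that exchanging the sulfur-bearing group for cyano does not move the read-out beyond the scatter, with both compounds still weak. No measured property bears on this step.

On these data alone, whether an amine, a carboxylic acid or a longer chain on this aromatic carbon would move the number beyond the scatter stays open. The direction of the cyano exchange also remains unsettled, since it rests on this single pair.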